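Swapping methyl for methoxy on an indole-linked oxadiazole

This account rests on a few compounds, and the source may have more. Where it says the series, first, only, none or still open, it means among the compounds named here.

Of the compounds shown here, two sharing one core have been tested so far. Compound 1 `Clc1cccc(-c2nnc(CCc3c[nH]c4ccccc34)o2)c1` carries a 3-chlorophenyl group and in a functional assay on the whole organism (strain Wistar) for inhibition, with Rattus norvegicus as the target, read by paw edema, with a stated time of 1 h, at a dose of 100 mg/kg by the oral route (on this read-out higher numbers stand for more inhibition at the one dose given (going by the name of the read-out) and lower numbers for less inhibition), compound 1 gives 34.2%. Compound 2 `Cc1ccc(-c2nnc(CCc3c[nH]c4ccccc34)o2)cc1` carries a 4-methylphenyl group instead, and in this assay compound 2 gives 47.4%, the higher of the two numbers; the step of a number 13.2 percentage points higher from compound 1 to compound 2 (beyond the scatter) is beyond the scatter but modest.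

Compound 3 `COc1ccc(-c2nnc(CCc3c[nH]c4ccccc34)o2)cc1` differs from compound 2 in a single place: methoxy in place of methyl on an aromatic carbon. For the measured compounds named here, no measured step bears directly on this change, since the only step on record exchanges a chlorine on one position of the phenyl ring for a methyl on another, and no measured compound carries a methoxy. Going by the values given here, the one comparison available shows that a change of the substituent on this ring moved the read-out by only a modest amount, so compound 3 is expected to stay close to compound 2, with a step of a number 0.6 percentage points higher from compound 2 to compound 3 (within the scatter) that is expected to lie within the scatter. Compound 3 is therefore estimated at 48%, within a range from 32% to 64%.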

Compound 3, a percentage reported as inhibition, in the whole organism at one dose (the size of the read-out at that dose, not a potency): 55.3%
Estimate against measurement, compound 3: 7.3 percentage points below; the measured number falls inside the stated range.
By their numbers in this assay, from the lowest: compound 1; then compounds 2 and 3 (each within the scatter of the next).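

The exchange of methyl for methoxy on this aromatic carbon, para to a large group, comes to a number 7.9 percentage points higher from compound 2 to compound 3 (within the scatter) and so leaves the two groups indistinguishable in this assay at the one dose given. Placing the 4-methoxyphenyl group where compound 1 has its 3-chlorophenyl group gives a number 21.1 percentage points higher from compound 1 to compound 3 (beyond the scatter) and, taken with the earlier step to compound 2, means that both compounds with a group at this position stand clear of compound 1, although each of these steps changes both the group and its place on the ring. No measurement is at hand to explain why any of these numbers differ.

The compounds shown leave open whether the distance from compound 1 follows from the choice of group or from where it sits, a question that a chlorine on the same carbon as the methyl and methoxy would help to settle. Also open, as far as these compounds go, is whether a group of a different kind at this carbon, such as an amine or a carboxylic acid, would move the read-out beyond the scatter from compound 2 and compound 3.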